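The source may hold more compounds than are shown below. What is called first, only, known or untested is meant among the compounds shown, and "the series" means these compounds.

Measured so far:
compound 1, `Nc1sc2c(c1-c1nc3cc(Cl)ccc3s1)CCCC2`, 107 ug/mL
compound 2, `Fc1ccc(/C=N/c2sc3c(c2-c2nc4ccccc4s2)CCCC3)cc1`, 277 ug/mL

Of the compounds shown here, two have been tested in an ADME assay on HeLa cells (Homo sapiens) for cytotoxicity, read by MTT assay, with a stated time of 72 h; a higher number here means that more compound is tolerated, a lower number that less compound is tolerated. Compound 2 has the higher of the two numbers, and the gap to compound 1, which gives 107 ug/mL, lies beyond the usual scatter. Compound 3 is `O=[N+]([O-])c1ccccc1/C=N/c1sc2c(c1-c1nc3ccccc3s1)CCCC2`; it differs from compound 2 in one place, (2-nitrophenyl in place of 4-fluorophenyl on a carbon with a double bond to nitrogen). For the measured compounds named here, no measured pair shows what this exchange does, so no step beyond the scatter is expected in either direction, with a slight lean downward. For compound 3 the estimated result in this assay is 220 ug/mL, within 110 ug/mL to 440 ug/mL. The expected step from compound 2 to compound 3 is therefore a 1.3-fold lower number from compound 2 to compound 3 (0.10 log units; within the scatter).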

Compound 3, half-maximal cytotoxic concentration: 369 ug/mL
Compound 3: the middle estimate sits 1.7-fold (0.22 log units) below what was measured, and the stated range covers the measured number.
By their numbers in this assay, from the lowest: compound 1; then compounds 2 and 3 (each within the scatter of the next).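

In this assay the exchange of 4-fluorophenyl for 2-nitrophenyl on a carbon with a double bond to nitrogen gives a 1.3-fold higher number from compound 2 to compound 3 (0.12 log units; within the scatter) and so stays within the scatter. This place therefore accepts a group with more heavy atoms and with hydrogen-bond acceptors without a step beyond the scatter. No available evidence accounts for this result.

As far as these compounds go, whether an amine or a carboxylic acid on the phenyl ring would also stay within the scatter remains open. The same holds for an alkyl chain in place of that ring.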